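The source may report more compounds than this note shows. Statements on the series, on what has been measured and on what is new or still open speak of the compounds shown alone.

Measured compounds:
compound 1 `O=C(CN(c1ncnc2c1ncn2C1CCCCO1)C1CC1)N[C@@H](CCC(=O)OCc1ccccc1)C(=O)OCc1ccccc1`, 20.7%
compound 2 `CC[C@H](C)[C@H](NC(=O)CN(c1ncnc2c1ncn2C1CCCCO1)C1CC1)C(=O)OCc1ccccc1`, 20.4%

Compound 2 stands lowest of the two numbers in a functional assay on the whole organism (Tail, strain ICR) with Mus musculus as the target, in the tail flick test, with a stated time of 120 min, at a dose of 25 umol/kg by the oral route (a higher number here means a stronger effect of the compound at the dose given, a lower number a weaker effect), with compound 1 nearest at a value within the scatter; the two cannot be ordered on what is shown. Compound 3 `O=C(CN(c1ncnc2c1ncn2C1CCCCO1)C1CC1)N[C@@H](CO)C(=O)OCc1ccccc1` is to be measured in this assay. It differs from compound 2 as follows: hydroxymethyl in place of sec-butyl on a saturated chain carbon bound to an amide-type nitrogen and a carbonyl carbon. Among the measured compounds shown here, the single measured step at the same place, a number 0.3 percentage points lower from compound 1 to compound 2 (within the scatter), bears on this change: it swapped one side chain for another and produced no shift beyond the scatter. That step exchanged two groups without donors or acceptors, whereas the group entering in compound 3 brings one hydrogen-bond donor and one acceptor, so the precedent is only partial. On the evidence shown the expectation for compound 3 is a step of a number 1.4 percentage points lower from compound 2 to compound 3 (within the scatter), that is, nothing clearly beyond the scatter, with a wider range to allow for the untested kind of change. The estimate for compound 3 in this assay is 19%, expected to fall between 8% and 31%.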

Compound 3, a percentage reported as activity, at one dose (the size of the read-out at that dose, not a potency): 29.2%
Compound 3: the middle estimate sits 10.2 percentage points below what was measured; low and high end bracket the measured number.
By their numbers in this assay, from the lowest: compounds 2, 1 and 3 (each within the scatter of the next).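

Working notes on the side chain on the saturated chain carbon bound to an amide-type nitrogen and a carbonyl carbon: in this assay, hydroxymethyl in place of sec-butyl gives a number 8.8 percentage points higher from compound 2 to compound 3 (within the scatter), and the comparison with the longer ester side chain, hydroxy in place of (benzyloxycarbonyl)methyl, gives a number 8.5 percentage points higher from compound 1 to compound 3 (within the scatter), so neither exchange separates the compounds. The earlier pair covered only side chains without a hydrogen-bond donor; these steps add that hydroxymethyl, which carries one and has fewer heavy atoms than sec-butyl, also leaves the read-out within the scatter at this place, and all three side chains remain unordered. No measurement on hand addresses why the read-out behaves this way at this place.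

Still open, going by these compounds, is whether an amine, a carboxylic acid or a longer hydroxyalkyl chain at this place would give a step beyond the scatter, and whether a methoxymethyl group would read like hydroxymethyl. With a single dose and a single stated time, the read-out gives the size of the effect under those conditions and not a potency for any compound in the series.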